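Swapping 3-chlorobenzyl for 3-hydroxyphenyl

This account rests on a few compounds, and the source may have more. Where it says the series, first, only, none or still open, it means among the compounds named here.

Compound 1 (`CCCCn1cnc2c(NCc3cccc(Cl)c3)nc(N[C@H]3CC[C@H](N)CC3)nc21`): 350 nM
Compound 2 (`CC(C)CCn1cnc2c(NCc3cccc(Cl)c3)nc(N[C@H]3CC[C@H](N)CC3)nc21`): 1330 nM

In a functional assay on EOL1 cells (Homo sapiens) for inhibition, read by fluorescence, with a stated time of 72 h (a higher number here means a weaker inhibitor of growth, a lower number a stronger inhibitor of growth), compound 2 has the higher of the two numbers. Compound 3 (`CC(C)CCn1cnc2c(Nc3cccc(O)c3)nc(N[C@H]3CC[C@H](N)CC3)nc21`) carries 3-hydroxyphenyl in place of 3-chlorobenzyl on a nitrogen on an aromatic ring. Going by the values given here, the one measured step (a 3.8-fold higher number from compound 1 to compound 2 (0.58 log units; beyond the scatter)) is modest and concerns the saturated chain instead, so it offers a scale but no direction for this change. A step of at least comparable size is expected, tentatively toward a lower number (a 4.4-fold lower number from compound 2 to compound 3 (0.65 log units; beyond the scatter)). For compound 3 the estimated value is 300 nM, with an expected range from 50 nM to 1500 nM.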

Compound 3, concentration for 50% growth inhibition: 60 nM
Beside the measured number, compound 3's estimate is 5.0-fold (0.70 log units) above it; measured number inside the range.
By their numbers in this assay, from the lowest: compound 3; then compound 1; then compound 2.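

In this assay the exchange on the nitrogen on an aromatic ring gives a 22-fold lower number from compound 2 to compound 3 (1.35 log units; beyond the scatter) and is called large, whereas the earlier change on the saturated chain was modest. Going by these compounds alone, this shows that the position, held as 3-chlorobenzyl in the earlier compounds, can move the growth-inhibition number strongly and toward a lower value. Nothing available accounts for this step. On these data alone, the exchange alters the ring substituent and the link to the nitrogen together, so the share of each remains open. A 3-chlorophenyl or 3-hydroxybenzyl group at this position would separate the two.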